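Phenylsulfonyl in place of methyl(phenyl)amino

The source may hold more compounds than are shown below. What is called first, only, known or untested is meant among the compounds shown, and "the series" means these compounds.

In a functional assay (aorta) with Oryctolagus cuniculus as the target (a lower number here means tighter binding, a higher number weaker binding), compound 1 `COc1ccccc1OCCCN1CCC(C(c2ccc(F)cc2)c2ccc(F)cc2)CC1` gives 2.51 nM and compound 2 `CN(CCCN1CCC(C(c2ccc(F)cc2)c2ccc(F)cc2)CC1)c1ccccc1` gives 2 nM, so compound 2 stands level with compound 1 within the scatter. Compound 3 `O=S(=O)(CCCN1CCC(C(c2ccc(F)cc2)c2ccc(F)cc2)CC1)c1ccccc1` differs from compound 2 at one place: phenylsulfonyl in place of methyl(phenyl)amino on a saturated chain carbon, three bonds along the chain from an amine nitrogen in a ring. The group sits on a saturated chain carbon, three bonds along the chain from an amine nitrogen in a ring. For the measured compounds named here, the only measured exchange there, a 1.3-fold lower number from compound 1 to compound 2 (0.10 log units; within the scatter), stayed within the scatter, and a single step is thin support. No change beyond the scatter is therefore expected, with an estimated 1.8-fold higher number from compound 2 to compound 3 (0.24 log units; within the scatter). Compound 3 is estimated at 3.5 nM, with an expected range of 1 nM to 12 nM.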

Compound 3, dissociation constant: 20 nM
Estimate against measurement, compound 3: 5.7-fold (0.76 log units) below; the whole stated range lies below it.
By their numbers in this assay, from the lowest: compounds 2 and 1 (each within the scatter of the next); then compound 3.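

In this assay this position turns out not to treat every group alike, with a 10-fold higher number from compound 2 to compound 3 (1.00 log units; beyond the scatter) and an 8.0-fold higher number from compound 1 to compound 3 (0.90 log units; beyond the scatter), while compound 1 and compound 2 had stood within the scatter of each other. Phenylsulfonyl is the first group shown at this place to move the number beyond the scatter. Nothing available explains this step.

Going by these compounds, whether phenylthio or benzoyl at the same place would stay level with compound 2 remains open. So does whether a longer chain carrying phenylsulfonyl would change the size of the step.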